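The source may hold more compounds than are shown below. What is called first, only, known or untested is meant among the compounds shown, and "the series" means these compounds.

Three compounds have been measured in a functional assay on COLO 205 cells (Homo sapiens) for cytotoxicity, read by MTT assay, with a stated time of 72 h; on this read-out lower numbers stand for stronger inhibition and higher numbers for weaker inhibition:

Compound 1 `COc1ccc(C(=O)c2cc(OC)c(OC)c(OC)c2)cc1NC(=O)/C=C/c1ccc(C(F)(F)F)cc1`: 2600 nM
Compound 2 `COc1ccc(C(=O)c2cc(OC)c(OC)c(OC)c2)cc1NC(=O)/C=C/c1cccc(OC(F)(F)F)c1`: 7900 nM
Compound 3 `COc1ccc(/C=C/C(=O)Nc2cc(C(=O)c3cc(OC)c(OC)c(OC)c3)cc(OC)c2OC)cc1OC`: 5700 nM

Compound 3 stands second highest of these three numbers. Its nearest neighbour is compound 2, whose value lies within the scatter of the value of compound 3, so no order between the two can be claimed. Compound 1 gives a lower number than compound 3, and that gap lies beyond the scatter.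

Compound 4 `COc1ccc(/C=C/C(=O)Nc2cc(C(=O)c3cc(OC)c(OC)c(OC)c3)cc(OC)c2OC)cc1N` has not yet been measured. It differs from compound 3 by amino in place of methoxy on an aromatic carbon.

Going by the values given here, only one step between measured compounds exists, a 3.0-fold higher number from compound 1 to compound 2 (0.48 log units; beyond the scatter), and it alters the substituents on the aryl ring of the ethenyl chain in a different way; it shows that changes on that ring can shift the number modestly, but it does not exchange methoxy for amino anywhere. The data therefore give no direct guide to the direction of the change from compound 3 to compound 4.

Compound 4 is expected to give about 4000 nM in this assay, within a range of 1200 nM to 13000 nM, which corresponds to an estimated step of a 1.4-fold lower number from compound 3 to compound 4 (0.15 log units; within the scatter).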

Compound 4, half-maximal inhibitory concentration: 10100 nM
Compound 4: middle estimate off by 2.5-fold (0.40 log units), on the low side, within the range that was stated.
By their numbers in this assay, from the lowest: compound 1; then compounds 3, 2 and 4 (each within the scatter of the next).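

In this assay, amino in place of methoxy gives a 1.8-fold higher number from compound 3 to compound 4 (0.25 log units; within the scatter) and so cannot be told apart from no change at all. Going by these compounds alone, this is the first reading at this place, ortho to a methoxy group and meta to a large group, since the only earlier step concerned other substituents on a different pair of compounds. Here 3,4-dimethoxyphenyl becomes 3-amino-4-methoxyphenyl, so one heavy atom is lost and one hydrogen-bond donor is gained, and on these two compounds neither exchange registers beyond the scatter, while no measurement is at hand that would explain this outcome.

As far as these compounds go, whether this place accepts other groups equally remains open: a hydroxyl, an acetamide, a dimethylamino group or a longer alkoxy chain might move the number beyond the scatter. From the compounds shown here alone, it is also open whether amino in place of the remaining methoxy on the same ring, or a carboxylic acid at either place, would leave the number just as close to that of compound 3.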